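One Methoxy Fewer: What Compound 3 May Show

A few compounds are considered here, and "the series" means these few. Any claim that something is new, unique, unknown or untested is made for them only; others in the source may bear on it.

Of the compounds shown here, two have a number so far in a functional assay on MCF7 cells (Homo sapiens) for antiproliferative activity, read by MTT assay, with a stated time of 48 h; a lower number here means a stronger inhibitor, a higher number a weaker inhibitor. Going by the values given here, compound 1 (`COc1cc(C(=O)/C=C/c2c[nH]c3ccccc23)cc(SC)c1OC`) gives 186 nM and compound 2 (`COc1ccc2c(/C=C/C(=O)c3cc(OC)c(OC)c(SC)c3)cn(C)c2c1`) gives 166 nM, and these two values lie within the usual scatter of each other, so compound 2 cannot be told apart from the only other measured compound. Compound 3 (`COc1cc(C(=O)/C=C/c2cn(C)c3ccccc23)cc(SC)c1OC`) has not yet been measured. It departs from compound 2 in one place (hydrogen in place of methoxy on an aromatic carbon), with hydrogen in place of methoxy on an aromatic carbon. Among the compounds with values here, no measured pair differing in one place exists, so the data hold no direct measure of such a swap in this assay. Within the data shown here, the only guide is that compound 1 at 186 nM and compound 2 at 166 nM sit close together, and no step beyond the scatter is expected, in either direction. The estimated 1.1-fold lower number from compound 2 to compound 3 (0.04 log units; within the scatter) is small and has no firm direction. Compound 3 is expected at 150 nM with a wide estimated range (50 nM to 450 nM).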

Compound 3, half-maximal inhibitory concentration: 102 nM
Beside the measured number, compound 3's estimate is 1.5-fold (0.17 log units) above it; measured number inside the range.
By their numbers in this assay, from the lowest: compounds 3, 2 and 1 (each within the scatter of the next).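

Going by these compounds alone, until now no pair differing in one place existed, and compound 3 supplies two of them. In this assay, hydrogen in place of methoxy on an aromatic carbon of the six-membered aromatic ring of carbon only, part of a fused or bridged system of two rings, gives a 1.6-fold lower number from compound 2 to compound 3 (0.21 log units; within the scatter), so at this position the methoxy is not needed to hold the number within the scatter. Methyl in place of hydrogen on an aromatic nitrogen gives a 1.8-fold lower number from compound 1 to compound 3 (0.26 log units; within the scatter), which likewise shows no step beyond the scatter for this change, and the data offer nothing that could account for either step.

Going by these compounds, each change has been read only once, on a single partner, so whether either would stay within the scatter on another compound remains open. Within the data shown here, it also remains open whether a chlorine atom, an amine or a carboxylic acid on that aromatic carbon, or a longer chain such as propyl on the aromatic nitrogen, would give a step beyond the scatter, since hydrogen and methoxy at the carbon and hydrogen and methyl at the nitrogen are the only groups compared there.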